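The compounds below may be only part of what the source reports. "The series", "measured", "known", "first", "only" and "open" are said of these compounds alone.

Compound 1 `NNC(=O)CCc1ccncc1-c1ccc2ccccc2c1` gives 7.7 nM in an assay on a protein complex for inhibition of CDK8/Cyclin C (Homo sapiens), with a stated time of 1 h (a higher number here means a weaker inhibitor, a lower number a stronger inhibitor), the lowest of the two numbers measured; compound 3 `O=C(CCc1ccncc1-c1ccc2ccccc2c1)N1CCOCC1` gives 45.5 nM, and compound 2 `CN1CCN(c2ccc(Nc3cnccc3/C=C/C(N)=O)cc2)CC1` has "not determined" (no result reported). Going by the values given here, the only measured step on the shared core, a 5.9-fold higher number from compound 1 to compound 3 (0.77 log units; beyond the scatter), exchanged the group on the carbonyl carbon and weakened inhibition modestly. Compound 4 `COC(=O)/C=C/c1ccncc1-c1ccc2ccccc2c1` differs from compound 1 in the same region: 2-(methoxycarbonyl)ethenyl in place of 2-(aminocarbamoyl)ethyl on an aromatic carbon. That change also removes the hydrogen-bond donors of the side chain, so by analogy with compound 3 and its step of a 5.9-fold higher number from compound 1 to compound 3 (0.77 log units; beyond the scatter) a modest weakening is expected rather than none, giving an expected step of a 4.5-fold higher number from compound 1 to compound 4 (0.66 log units; beyond the scatter). Compound 4 is therefore estimated at 35 nM in this assay, within a range from 9 nM to 140 nM.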

Compound 4, half-maximal inhibitory concentration: 40.6 nM
Beside the measured number, compound 4's estimate is 1.2-fold (0.06 log units) below it; low and high end bracket the measured number.
By their numbers in this assay, from the lowest: compound 1; then compounds 4 and 3 (each within the scatter of the next).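

Replacing 2-(aminocarbamoyl)ethyl with 2-(methoxycarbonyl)ethenyl gives a 5.3-fold higher number from compound 1 to compound 4 (0.72 log units; beyond the scatter) in this assay, so a change to the whole side chain, and not only to the group on the carbonyl carbon as in compound 3, also weakens inhibition. This single step alters the hydrogen-bond donor count and the number of double bonds together, so it cannot show which change matters. No available evidence explains the loss. Still open, going by these compounds, is how a saturated 2-(methoxycarbonyl)ethyl chain or a carboxylic acid at this position would compare with compound 1.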